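A Second Amide in Place of an Aromatic Ring

This account rests on a few compounds, and the source may have more. Where it says the series, first, only, none or still open, it means among the compounds named here.

Three relatives sharing one core have been tested in an ADME assay on MT4 cells (Homo sapiens) for cytotoxicity, read by MTT assay; a higher number here means that more compound is tolerated, a lower number that less compound is tolerated. Compound 1 `Cc1cc(C)cc(S(=O)(=O)c2c(C(=O)NCc3cccc(F)c3F)[nH]c3ccc(Cl)cc23)c1` reads > 51100 nM, which is a limit of the assay. Compound 2 `COc1cccc(F)c1CNC(=O)c1[nH]c2ccc(Cl)cc2c1S(=O)(=O)c1cc(C)cc(C)c1` reads > 49900 nM, which is also a limit, so it has no exact number. Replacing 2,3-difluorophenyl with 2-fluoro-6-methoxyphenyl gives a step that the two limits leave unreadable from compound 1 to compound 2, so this measured step offers no size to carry forward.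

Compound 4 `Cc1cc(C)cc(S(=O)(=O)c2c(C(=O)NCC(=O)NC(C)c3ccncc3)[nH]c3ccc(Cl)cc23)c1`, not yet measured, carries (1-(pyridin-4-yl)ethyl)carbamoyl in place of 2-fluoro-6-methoxyphenyl on a saturated chain carbon bound to an amide-type nitrogen. The closest guide is compound 3 `Cc1cc(C)cc(S(=O)(=O)c2c(C(=O)NC(C)C(=O)NC(C)c3ccccc3)[nH]c3ccc(Cl)cc23)c1`, whose chain also runs on through a second amide and which gives a true number, 21700 nM. On that evidence, the expected change is a modest move toward less compound being tolerated, an estimated at least 1.6-fold lower number from compound 2 to compound 4 (0.22 log units; that floor lies within the scatter). For compound 4, the estimate is 30000 nM, with an expected range from 12000 nM to 60000 nM.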

Compound 4, half-maximal cytotoxic concentration: 47000 nM
Compound 4: middle estimate off by 1.6-fold (0.19 log units), on the low side; the range from low to high includes it.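

In this assay, for the compounds shown here, compound 4 gives a true number, 47000 nM, so (1-(pyridin-4-yl)ethyl)carbamoyl on a saturated chain carbon bound to an amide-type nitrogen yields the first exact reading for a change at this place. Both starting values are limits, so the change can be read only as an at least 1.0-fold lower number from compound 2 to compound 4 (0.02 log units; that floor lies within the scatter) and as an at least 1.0-fold lower number from compound 1 to compound 4 (0.03 log units; that floor lies within the scatter), and neither floor shows a real drop. For compound 2, the starting point is a limit and not a number: the limit of > 49900 nM in this assay, at which 1 of the 4 values shown sits.

On these data alone, the true size of either step stays open, as the starting compounds have no exact numbers. Also open, as far as these compounds go, is how a carboxylic acid or a primary amine at the end of a longer chain would read at this place.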